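A few compounds are considered here, and "the series" means these few. Any claim that something is new, unique, unknown or untested is made for them only; others in the source may bear on it.

Compound 1 `CCOC(=O)c1c(-c2ccc(Cl)cc2)[nH]c2cccc(OC)c2c1=O` was tested in a physicochemical assay for solubility, in phosphate buffer, at pH 7.4; on this read-out higher numbers stand for higher solubility and lower numbers for lower solubility. In this assay compound 1 gives > 100000 nM, which is a limit of the assay rather than a number. Compound 2 `CCOC(=O)c1c(-c2cccs2)[nH]c2cc(OC)ccc2c1=O` gives > 100000 nM in this assay, again only a limit. Both results therefore sit at the limit of > 100000 nM in this assay, at which 2 of the 2 values shown sit, so compound 1 stands at the top edge of what this assay can report, alongside compound 2. Compound 3 `CCOC(=O)c1c(-c2cccc(C)c2)[nH]c2cccc(OC)c2c1=O` carries one change from compound 1: 3-methylphenyl in place of 4-chlorophenyl on an aromatic carbon. Among the measured compounds shown here, no measured step between two compounds is available to gauge this change, so only a step within the usual scatter is expected, a number no higher from compound 1 to compound 3 (the limit leaves the size open). Compound 3 is accordingly expected to give about 100000 nM, somewhere between 40000 nM and 250000 nM, most likely again reported as a limit.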

Compound 3, solubility: > 100000 nM
Compound 3: no number, only a limit (the forecaster's own chance of this, stated with the estimate: 70%); the middle value sits exactly at the limit.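

In this assay, among the compounds shown here, compound 1 and compound 3 both give a limit rather than a number, so no step between them can be read: the limit of > 100000 nM in this assay, at which 3 of the 3 values shown sit. The compounds shown leave open how soluble each one really is, and whether 3-methylphenyl in place of 4-chlorophenyl makes any difference.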